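The source may hold more compounds than are shown below. What is called first, only, known or untested is meant among the compounds shown, and "the series" means these compounds.

Compound 2 `Cc1ccc(S(=O)(=O)N[C@@H](CC(=O)NC(C)(C)C)C(=O)NCCNC(=O)c2ccc(F)cc2)cc1` is one of three close analogues that share a core and differ only in the aryl group on the carbonyl carbon. In an ADME assay on Karpas-1106P cells (Homo sapiens) for cytotoxicity (a lower number here means that less compound is needed, a higher number that more compound is needed for the effect), compound 2 gives > 11100 nM, which is a limit of the assay and not a number. Compound 1 `Cc1ccc(S(=O)(=O)N[C@@H](CC(=O)NC(C)(C)C)C(=O)NCCNC(=O)c2cccc(C(C)C)c2)cc1` carries 3-isopropylphenyl at that position; in this assay compound 1 gives > 11100 nM, again a limit. Compound 3 `Cc1ccc(S(=O)(=O)N[C@@H](CC(=O)NC(C)(C)C)C(=O)NCCNC(=O)c2cc(C)ccc2F)cc1` carries 2-fluoro-5-methylphenyl; in this assay compound 3 gives > 11100 nM, also a limit. Because of the limit of > 11100 nM in this assay, at which 3 of the 3 values shown sit, none of the three steps can be read: the step that the two limits leave unreadable from compound 1 to compound 2, the step that the two limits leave unreadable from compound 1 to compound 3 and the step that the two limits leave unreadable from compound 2 to compound 3 are all hidden by the limit. Compound 4 `Cc1ccc(S(=O)(=O)N[C@@H](CC(=O)NC(C)(C)C)C(=O)NCCNC(=O)c2ccc(F)c(F)c2)cc1` differs from compound 2 by fluoro in place of hydrogen on an aromatic carbon. Going by the values given here, no measured step bears on this change in a readable way; the three analogues show only that changes on this aryl group have not brought any compound below the limit. The step from compound 2 to compound 4 is therefore expected to be a number no higher from compound 2 to compound 4 (the limit leaves the size open) in this assay, with no direction beyond the scatter. For compound 4 the estimate in this assay is 11100 nM, with a range from 5500 nM to 30000 nM.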

Compound 4, half-maximal effective concentration: > 11100 nM
Compound 4 was reported as a limit; the forecaster's own chance of this, stated with the estimate: 85%; the middle value lies on the limit itself.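

In this assay compound 4 gives > 11100 nM, which is a limit and not a number, so its steps from compound 1, compound 2 and compound 3 cannot be read: the limit of > 11100 nM in this assay, at which 4 of the 4 values shown sit. The compounds shown leave open what actual value any of these four compounds has in this assay.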